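The source may report more compounds than this note shows. Statements on the series, on what has been measured and on what is new or still open speak of the compounds shown alone.

Among the measured compounds shown here, compound 1 `O=C1N=C(N2N=C(c3ccccc3)CC2c2ccccc2O)S/C1=C1/C(=O)Nc2ccccc21` gives 5370 nM in a functional assay on cells (Cancer cell lines, Homo sapiens) for cytotoxicity, read by sulforhodamine B assay, with a stated time of 48 h (on this read-out lower numbers stand for stronger inhibition of growth and higher numbers for weaker inhibition of growth), the highest number among the three measured members. For the measured compounds named here, compound 2 `O=C1N=C(N2N=C(c3ccccc3)CC2c2ccccc2O)S/C1=C1/C(=O)Nc2ccc(Br)cc21` gives 720 nM in this assay, and the single known step is a 7.5-fold lower number from compound 1 to compound 2 (0.87 log units; beyond the scatter). Going by the values given here, compound 3 `Cc1ccc2c(c1)/C(=C1\SC(N3N=C(c4ccccc4)CC3c3ccc(Cl)cc3)=NC1=O)C(=O)N2` gives 320 nM in this assay but differs from compound 1 in more than one place, so no single step is drawn from that pair. Compound 4 `CN(C)c1ccc(C2CC(c3ccccc3)=NN2C2=NC(=O)/C(=C3\C(=O)Nc4ccccc43)S2)cc1` differs from compound 1 by 4-(dimethylamino)phenyl in place of 2-hydroxyphenyl on a saturated ring carbon. Among the compounds with values here, no measured step touches this saturated ring carbon, so nothing bears directly on the change; the only step in hand concerns a different position. For compound 4 the expected step is therefore a 1.3-fold lower number from compound 1 to compound 4 (0.13 log units; within the scatter), with no direction beyond the scatter. Compound 4 is thus estimated at 4000 nM in this assay, within 1000 nM to 12000 nM.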

Compound 4, concentration for total growth inhibition: 3240 nM
For compound 4 the middle estimate is 1.2-fold (0.09 log units) above the measured one, within the range that was stated.
By their numbers in this assay, from the lowest: compound 3; then compound 2; then compounds 4 and 1 (each within the scatter of the next).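

In this assay, among the compounds shown here, this is the first measured change on the saturated ring carbon, and a 1.7-fold lower number from compound 1 to compound 4 (0.22 log units; within the scatter) shows that 4-(dimethylamino)phenyl in place of 2-hydroxyphenyl does not move the number beyond the scatter. The entering group has no hydrogen-bond donor and more heavy atoms than the leaving group, yet this pair shows no separation. Nothing measured bears on the reason for this result. Open, on these data alone, is whether a carboxylic acid on that phenyl ring, or a longer alkyl chain at this carbon, also stays within the scatter of compound 1. Also open, as far as these compounds go, is whether bromo in place of hydrogen on an aromatic carbon gives a similar step from compound 4.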